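From 3-Methoxyphenyl to 4-Fluorophenyl on a Shared Core

A few compounds are considered here, and "the series" means these few. Any claim that something is new, unique, unknown or untested is made for them only; others in the source may bear on it.

In a functional assay on HepG2 cells (Homo sapiens) for antiproliferative activity, read by MTT assay, with a stated time of 48 h (on this read-out lower numbers stand for stronger inhibition and higher numbers for weaker inhibition), compound 1 (`COc1ccc(-c2ccc3c(c2)C(=O)C(=O)N3Cc2ccc(Cl)c(Cl)c2)cc1`) gives 990 nM, compound 2 (`COc1ccc(-c2ccc3c(c2)C(=O)C(=O)N3Cc2ccc3ccccc3c2)cc1`) gives 380 nM and compound 3 (`COc1ccc(CN2C(=O)C(=O)c3cc(-c4cccc(OC)c4)ccc32)cc1`) gives 1890 nM. Compound 3 therefore stands within the scatter of compound 1, while its number lies above that of compound 2 by more than the scatter. Compound 4 (`COc1ccc(CN2C(=O)C(=O)c3cc(-c4ccc(F)cc4)ccc32)cc1`) departs from compound 3 at a single place, with 4-fluorophenyl in place of 3-methoxyphenyl on an aromatic carbon. Among the measured compounds shown here, the only measured step, a 2.6-fold lower number from compound 1 to compound 2 (0.42 log units; beyond the scatter), is modest and beyond the scatter, but it concerns naphthalen-2-yl in place of 3,4-dichlorophenyl on a saturated chain carbon, which is a different place in the molecule. For the measured compounds named here, no measured step covers the aromatic carbon that changes here, so the data offer only weak guidance. No change beyond the scatter is expected, and the estimated step is a 1.3-fold lower number from compound 3 to compound 4 (0.10 log units; within the scatter). Compound 4 is expected at 1500 nM, with an estimated range of 600 nM to 3700 nM.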

Compound 4, half-maximal inhibitory concentration: 3150 nM
The estimate for compound 4 lay 2.1-fold (0.32 log units) below the measured number, within the range that was stated.
By their numbers in this assay, from the lowest: compound 2; then compounds 1, 3 and 4 (each within the scatter of the next, the first and the last beyond it).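

Among the compounds shown here, this is the first measured step at this aromatic carbon: in this assay, the exchange of 3-methoxyphenyl for 4-fluorophenyl gives a 1.7-fold higher number from compound 3 to compound 4 (0.22 log units; within the scatter), so it stays within the scatter. For the compounds shown here, on the core of compound 3, then, a ring carrying one hydrogen-bond acceptor and a ring carrying none cannot be told apart by this read-out, whereas the only earlier step concerned the saturated chain carbon. No supporting evidence bears on this result.

The pair cannot separate the loss of the methoxy group from the arrival of the fluorine, since the substituent and its ring position change together. Nor do these compounds show whether a phenyl ring bearing a carboxylic acid or an amine at this aromatic carbon would stay within the scatter, or whether the exchange would read the same with the naphthalen-2-yl group of compound 2.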